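The source may report more compounds than this note shows. Statements on the series, on what has been measured and on what is new or still open speak of the compounds shown alone.

Within the data shown here, compound 2 `COc1ccc(C(=O)/C=C/c2ccc(OCc3cn(Cc4ccc(F)cc4)nn3)cc2)cc1` is the lower of the two compounds measured so far: in a functional assay on MIA PaCa-2 cells (Homo sapiens) for inhibition, read by MTT assay, with a stated time of 48 h, tested at 10 uM (on this read-out higher numbers stand for more inhibition of growth at the one concentration tested and lower numbers for less inhibition of growth), compound 2 gives 6%. Among the measured compounds shown here, its only neighbour, compound 1 `COc1ccc(C(=O)/C=C/c2ccc(OCc3cn(Cc4cccc(Br)c4)nn3)cc2)cc1`, gives 50% in this assay, and the step of a number 44 percentage points lower from compound 1 to compound 2 (beyond the scatter) is the single measured step that is known. Compound 3 `O=C(/C=C/c1ccc(OCc2cn(Cc3ccc(F)cc3)nn2)cc1)c1ccc([N+](=O)[O-])cc1` has not been measured; it differs from compound 2 by nitro in place of methoxy on an aromatic carbon. For the measured compounds named here, no measured step bears on this position: the one known step, from compound 1 to compound 2, changed the group on the saturated chain carbon bound to an aromatic nitrogen, a different part of the shared core. Going by the values given here, with no step to lean on, only a modest change is expected, and the step of a number 14 percentage points higher from compound 2 to compound 3 (beyond the scatter) is an estimate without a measured precedent. Compound 3 is therefore expected to give about 20% in this assay, within a range from 0% to 50%.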

Compound 3, percent growth inhibition at one concentration: 44%
The estimate for compound 3 lay 24 percentage points below the measured number, within the range that was stated.
By their numbers in this assay, from the lowest: compound 2; then compounds 3 and 1 (each within the scatter of the next).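

The position on the aromatic ring of the carbonyl side, untouched by the earlier pair, turns out to matter: with the 4-fluorophenyl group held constant, nitro in place of methoxy gives a number 38 percentage points higher from compound 2 to compound 3 (beyond the scatter) in this assay, a large step. Growth inhibition at the one concentration tested therefore responds to changes at two separate sites of the shared core, since a number 44 percentage points lower from compound 1 to compound 2 (beyond the scatter) is also large. Nothing available explains why this exchange of groups has such an effect.

The compounds shown leave open whether the same exchange would change the number in the same way with the 3-bromophenyl group in place of 4-fluorophenyl. They also leave open how an amine or a carboxylic acid at this position would read in this assay.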